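The source may hold more compounds than are shown below. What is called first, only, known or untested is meant among the compounds shown, and "the series" means these compounds.

Measured in a functional assay on RBL-2H3 cells (Rattus norvegicus) for inhibition, read by neutral red uptake, with stated times of 30 min and 1 h; a higher number here means a weaker inhibitor, a lower number a stronger inhibitor:
Compound 1 `COc1ccc(CN(CCN(C)C)c2ccc(Cl)cc2)cc1`: 18.1 nM
Compound 2 `COc1ccc(CN(CCN(C)C)c2ccc(N)cc2)cc1`: 2310 nM
Compound 3 `COc1ccc(CN(CCN(C)C)c2ccc(Cl)cn2)cc1`: 10.6 nM

In this assay, compound 3 gives 10.6 nM. It cannot be told apart from compound 1, with a 1.7-fold lower number from compound 1 to compound 3 (0.23 log units; within the scatter), and it stands far from compound 2, with a 220-fold lower number from compound 2 to compound 3 (2.34 log units; beyond the scatter).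

Compound 4 `COc1ccc(CN(CCN(C)C)c2ccc(N)cn2)cc1` has not yet been measured. It differs from compound 3 in one place, where 5-chloropyridin-2-yl gives way to 5-aminopyridin-2-yl, amino in place of chloro on an aromatic carbon.

Going by the values given here, the closest precedent is the same exchange on the 4-chlorophenyl group of compound 1, which was large: a 130-fold higher number from compound 1 to compound 2 (2.11 log units; beyond the scatter). Among the compounds with values here, the other step that bears on it is the exchange of 4-chlorophenyl for 5-chloropyridin-2-yl, which stayed within the scatter at a 1.7-fold lower number from compound 1 to compound 3 (0.23 log units; within the scatter), so it offers no sign that the precedent should fail to carry over. Within the data shown here, still, that precedent is a single pair, and no other pair tests it.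

A large rise in the number, meaning a much weaker inhibitor, is therefore expected, and the estimated change is a 130-fold higher number from compound 3 to compound 4 (2.12 log units; beyond the scatter). For compound 4 the estimated value is 1400 nM, with an expected range from 350 nM to 5000 nM.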

Compound 4, half-maximal inhibitory concentration in the RBL-2H3 assay: 1340 nM
Compound 4: the middle estimate sits 1.0-fold (0.02 log units) above what was measured; measured number inside the range.
By their numbers in the RBL-2H3 assay, from the lowest: compounds 3 and 1 (each within the scatter of the next); then compounds 4 and 2 (each within the scatter of the next).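

In the RBL-2H3 assay, compound 4 shows that the exchange of chloro for amino is not tied to the core of compound 1, with a 130-fold higher number from compound 3 to compound 4 (2.10 log units; beyond the scatter), and the change now stands on two cores at nearly the same size: the same change on two cores in the RBL-2H3 assay, a 130-fold higher number (2.11 log units; beyond the scatter) from compound 1 to compound 2 and a 130-fold higher number (2.10 log units; beyond the scatter) from compound 3 to compound 4, 1.0-fold (0.00 log units) apart, within the scatter of two such steps

In the RBL-2H3 assay, the ring nitrogen makes no difference that can be read once amino is in place, with a 1.7-fold lower number from compound 2 to compound 4 (0.24 log units; within the scatter), while the step from the chloro compound stays large, with a 74-fold higher number from compound 1 to compound 4 (1.87 log units; beyond the scatter), so across these compounds the loss follows the amino group and not the ring. The same exchange also comes with a clear drop in the partition coefficient in a physicochemical assay for lipophilicity; a higher number here means a more lipophilic compound, a lower number a more polar compound: the measured partition coefficient of compound 3, 3.87, and of compound 4, 2.56, a number 1.31 log units lower (beyond the scatter) In the physicochemical assay, compound 3 gives 3.87 and compound 4 gives 2.56.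

The compounds shown give that drop for one pair only, so they cannot tie it to the loss of inhibition. They also leave open whether the loss is particular to amino or would follow other groups at this place, such as a hydroxyl, a methyl or an acetamide.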